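From hydrogen to bromo at the limit of inhibition

The compounds below may be only part of what the source reports. "The series", "measured", "known", "first", "only" and "open" are said of these compounds alone.

In a functional assay on KB cells (Homo sapiens) for inhibition (a higher number here means a weaker inhibitor, a lower number a stronger inhibitor), compound 3 (`OCCOCn1cnc2c(Cl)c(Cl)ccc21`) gives > 100000 nM, which is a limit and not a number. Compound 1 (`OCCOCn1c(Cl)nc2c(Cl)c(Cl)ccc21`) gives > 100000 nM, which is also a limit. Compound 2 (`OCCOCn1c(SCc2ccccc2)nc2c(Cl)c(Cl)ccc21`) alone gives a number, 35000 nM. Most of the series therefore sits at the limit of > 100000 nM in this assay, at which 2 of the 3 values shown sit.

Compound 4 (`OCCOCn1c(Br)nc2c(Cl)c(Cl)ccc21`) follows from compound 3 by bromo in place of hydrogen on an aromatic carbon between two ring nitrogen atoms, next to the ring atom that bears a (2-hydroxyethoxy)methyl group.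

The nearest measured change is chloro giving way to hydrogen on that same carbon, a step that the two limits leave unreadable from compound 1 to compound 3, which cannot be sized. The two readable steps, an at least 2.8-fold lower number from compound 1 to compound 2 (0.45 log units; beyond the scatter) and an at least 2.8-fold higher number from compound 2 to compound 3 (0.45 log units; beyond the scatter), both concern benzylsulfanyl, so they are a weaker guide to a single halogen. The expectation therefore follows compound 1, the chloro counterpart, with its > 100000 nM as the reason, and a limit is all that this gives.

For the step itself, the estimate is an at least 1.1-fold lower number from compound 3 to compound 4 (0.04 log units; that floor lies within the scatter), with no clear change expected. Compound 4 is estimated at 90000 nM, with an expected range from 40000 nM to 200000 nM.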

Compound 4, half-maximal inhibitory concentration: > 100000 nM
Compound 4: a limit, no number; the forecaster's own chance of this, stated with the estimate: 65%; at least 1.1-fold (0.04 log units) between middle value and limit.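

With bromo on the aromatic carbon between two ring nitrogen atoms, a second halogen joins chloro and hydrogen at this position without giving a number in this assay, and the steps among compounds 1, 3 and 4 cannot be read. Among the compounds shown here, the one readable step, an at least 2.8-fold higher number from compound 2 to compound 4 (0.45 log units; beyond the scatter), shows that bromo, like chloro and hydrogen, does not match what benzylsulfanyl gives on this carbon, and compound 2 is the only compound that goes against this shared result. The series now gathers even more closely at a single mark: the limit of > 100000 nM in this assay, at which 3 of the 4 values shown sit.

The compounds shown leave open whether an amine, a methylsulfanyl group or a benzyloxy group on this carbon would also give a number in this assay, or whether this is particular to benzylsulfanyl. They also leave open whether hydrogen, chloro and bromo differ from one another at all, since the values of compounds 1, 3 and 4 are limits and can place none of the three relative to the others.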